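The compounds below may be only part of what the source reports. "The series", "measured", "known", "first", "only" and "open" are said of these compounds alone.

In an assay for inhibition of Amine oxidase [flavin-containing] B (Homo sapiens) (a higher number here means a weaker inhibitor, a lower number a stronger inhibitor), compound 1 `NC1CCCCC1Cc1ccccc1` gives 1940000 nM.
In this assay compound 2 `CN(C)C1CCCCC1Cc1ccccc1` gives 2300000 nM.
In this assay compound 3 `NC1C=C(c2ccccc2)CCC1` gives 510000 nM.

Among these three measured compounds, compound 3 gives the lowest number in this assay, and the numbers for compound 1 and compound 2 both lie well above it. Compound 4 `CN(C)C1C=C(c2ccccc2)CCC1` has not yet been measured. It differs from compound 3 in one place: dimethylamino in place of amino on a saturated ring carbon.

The same exchange has been seen once before among the measured compounds, in the pair of compound 1 and compound 2, which share a core and differ only in this group. That step, a 1.2-fold higher number from compound 1 to compound 2 (0.07 log units; within the scatter), stayed within the scatter of the assay. Among the measured compounds shown here, the only precedent therefore points to a change too small to tell apart from repeat measurements, and the expectation for compound 4 is a number close to that of compound 3, with a step of a 1.2-fold higher number from compound 3 to compound 4 (0.07 log units; within the scatter) expected. The estimate for compound 4 in this assay is 600000 nM, with a range from 250000 nM to 1500000 nM.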

Compound 4, inhibition constant: 1040000 nM
Estimate against measurement, compound 4: 1.7-fold (0.24 log units) below; the measured number falls inside the stated range.
By their numbers in this assay, from the lowest: compound 3; then compounds 4, 1 and 2 (each within the scatter of the next, the first and the last beyond it).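

Among the compounds shown here, on the core of compound 3, this exchange gives a step of a 2.0-fold higher number from compound 3 to compound 4 (0.31 log units; beyond the scatter) in this assay, the first reading of dimethylamino in place of amino that passes the scatter. This shows that the exchange at this saturated ring carbon can register as a modest change, although it did not do so on the core of compound 1. Even so, no dependence on the core can be claimed, because the two steps do not differ by more than scatter alone would allow: the same change on two cores in this assay, a 1.2-fold higher number (0.07 log units; within the scatter) from compound 1 to compound 2 and a 2.0-fold higher number (0.31 log units; beyond the scatter) from compound 3 to compound 4, 1.7-fold (0.24 log units) apart, within the scatter of two such steps.

Only amino and dimethylamino are shown at this position, so what methylamino or diethylamino would give on either core stays open. The compounds also cannot tell what lies behind the step, or whether a third core would show it.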